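A few compounds are considered here, and "the series" means these few. Any claim that something is new, unique, unknown or untested is made for them only; others in the source may bear on it.

Working notes on the series

Within the data shown here, compound 1 `O=c1oc2ccc(Cl)cc2c(O)c1C(c1cccc([N+](=O)[O-])c1)c1c(O)c2cc(Cl)ccc2oc1=O` carries a 3-nitrophenyl group on the saturated chain carbon bound to two aromatic carbons; in an assay on isolated protein for inhibition of Maltase-glucoamylase (Homo sapiens) (on this read-out lower numbers stand for stronger inhibition and higher numbers for weaker inhibition), compound 1 gives 27100 nM, the lowest of the three numbers measured so far. Compound 2 `COc1cc(C(c2c(O)c3cc(Cl)ccc3oc2=O)c2c(O)c3cc(Cl)ccc3oc2=O)ccc1O` gives 83600 nM and compound 3 `CCOc1cc(C(c2c(O)c3cc(Cl)ccc3oc2=O)c2c(O)c3cc(Cl)ccc3oc2=O)ccc1O` gives 57100 nM in this assay, so compound 1 stands ahead of both, with the gap to compound 3 nearer and the gap to compound 2 wider.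

The next change to follow leads to compound 4 `COc1ccc(C(c2c(O)c3cc(Cl)ccc3oc2=O)c2c(O)c3cc(Cl)ccc3oc2=O)cc1OC`: 3,4-dimethoxyphenyl in place of 3-nitrophenyl on a saturated chain carbon bound to two aromatic carbons. Among the measured compounds shown here, two measured steps bear on this, both replacing the 3-nitrophenyl group at the same place with an alkoxy-substituted phenyl: a 3.1-fold higher number from compound 1 to compound 2 (0.49 log units; beyond the scatter) and a 2.1-fold higher number from compound 1 to compound 3 (0.32 log units; beyond the scatter). Both moved the number upward by a modest amount. Compound 4 differs from compounds 2 and 3 in having two methoxy groups and no hydroxyl, a variant not yet covered by any measured pair; the nearest measured pair, a 1.5-fold lower number from compound 2 to compound 3 (0.17 log units; within the scatter), shows that changing the alkoxy group itself made little difference.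

On that basis a modest step upward is expected for compound 4, a 2.2-fold higher number from compound 1 to compound 4 (0.35 log units; beyond the scatter), with compound 4 estimated at 60000 nM in this assay, in the range 25000 nM to 150000 nM.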

Compound 4, half-maximal inhibitory concentration: 91400 nM
Beside the measured number, compound 4's estimate is 1.5-fold (0.18 log units) below it; measured number inside the range.
By their numbers in this assay, from the lowest: compound 1; then compounds 3, 2 and 4 (each within the scatter of the next).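

With 3,4-dimethoxyphenyl in place of 3-nitrophenyl on the saturated chain carbon bound to two aromatic carbons, the result is a 3.4-fold higher number from compound 1 to compound 4 (0.53 log units; beyond the scatter); all three alkoxy-bearing phenyl groups now stand on the same side of compound 1, and no compound shown goes against this. The new result also tests a phenyl group with no free hydroxyl: methyl on the oxygen gives a 1.1-fold higher number from compound 2 to compound 4 (0.04 log units; within the scatter), and the comparison with the ethoxy compound gives a 1.6-fold higher number from compound 3 to compound 4 (0.20 log units; within the scatter), so in this assay compounds 2, 3 and 4 are not separated, and the free hydroxyl shows no effect on the number beyond the scatter. No measured information bears on the reason for the gap between compound 1 and these three compounds.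

Compound 1 is the only compound shown with a nitro group, so it remains open whether its lower number goes with that group or simply with the lack of alkoxy groups. A plain phenyl, or an amine or a carboxylic acid in place of the nitro group, would separate these two readings, and a longer chain on the oxygen would extend the alkoxy comparison.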